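The source may hold more compounds than are shown below. What is called first, only, known or untested is meant among the compounds shown, and "the series" means these compounds.

Compound 1, `COc1ccc2c(=O)c(/C=C/C(=O)Nc3ccccc3OC)coc2c1`, gives > 200000 nM in a functional assay on L02 cells (Homo sapiens) for inhibition, read by MTT assay, with a stated time of 48 h; a higher number here means a weaker inhibitor, a lower number a stronger inhibitor; this is a limit of the assay.
Compound 2, `COc1ccc(NC(=O)/C=C/c2coc3cc(OC)ccc3c2=O)cc1`, gives > 200000 nM in this assay; this too is a limit.

Compound 2 therefore stands only at a limit of this assay, with no number of its own. For the measured compounds named here, the one step measured so far, a step that the two limits leave unreadable from compound 1 to compound 2, cannot be read, because of the limit of > 200000 nM in this assay, at which 2 of the 2 values shown sit. Compound 3, `COc1cccc(NC(=O)/C=C/c2coc3cc(OC)ccc3c2=O)c1`, is the next compound. Its change from compound 2 is 3-methoxyphenyl in place of 4-methoxyphenyl on an amide-type nitrogen. Going by the values given here, the one measured step moved a methoxy group around the same ring, and it gave no readable size, so there is nothing to show that such a shift alters the result. The step from compound 2 to compound 3 is therefore expected to be none beyond the scatter, a step that the limit leaves unreadable from compound 2 to compound 3, with compound 3 most likely again reaching only the limit. Compound 3 is estimated at 250000 nM in this assay, in the range 100000 nM to 700000 nM.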

Compound 3, half-maximal inhibitory concentration: > 200000 nM
Compound 3: a limit, no number; the forecaster's own chance of this, stated with the estimate: 85%; the middle value is on the limit's open side.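

No step between compound 1, compound 2 and compound 3 can be read, because each result is a limit rather than a number: the limit of > 200000 nM in this assay, at which 3 of the 3 values shown sit.

The compounds shown leave open whether 2-methoxyphenyl, 3-methoxyphenyl and 4-methoxyphenyl differ at all in this assay.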